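Swapping a Phenyl for an Aminothiazole on the Amide

The source may report more compounds than this note shows. Statements on the series, on what has been measured and on what is new or still open speak of the compounds shown alone.

Of the compounds shown here, two sharing one core have been tested in an assay on HEK293 cells for agonist activity at Toll-like receptor 8 (Homo sapiens), read by a luciferase reporter, with a stated time of 6 h; a higher number here means that more compound is needed for the effect, a lower number that less compound is needed. Compound 1, `CCCCNc1nc(N)nc2c1CCN(C)C2`, gives 0.2 uM. Compound 2, `CCCCNc1nc(N)nc2c1CN(C(=O)c1ccccc1)CC2`, gives 1.4 uM; of the two numbers, compound 2 stands highest, and its gap to compound 1 lies beyond the usual scatter. The untested compound 3, `CCCCNc1nc(N)nc2c1CN(C(=O)c1csc(N)n1)CC2`, differs from compound 2 in one place: 2-amino-1,3-thiazol-4-yl in place of phenyl on a carbonyl carbon. Going by the values given here, no measured pair shows this same change, so no step size can be read off for it; only the starting point is known, where compound 2 gives 1.4 uM. A step of a 1.4-fold lower number from compound 2 to compound 3 (0.15 log units; within the scatter) is expected, small enough to sit within or only just beyond the scatter, in no firm direction. Compound 3 is thus expected to give 1 uM, with a range from 0.3 uM to 4 uM.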

Compound 3, minimum effective concentration: 6.9 uM
Compound 3: middle estimate off by 6.9-fold (0.84 log units), on the low side; the measured number lies above the stated range.
By their numbers in this assay, from the lowest: compound 1; then compound 2; then compound 3.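

This carbonyl position is not indifferent to the group it carries: in this assay the change brings a 4.9-fold higher number from compound 2 to compound 3 (0.69 log units; beyond the scatter) and so more compound is needed for the effect. The step arises although the phenyl and the 2-amino-1,3-thiazol-4-yl have the same heavy-atom count, while their ring size, hetero atoms and hydrogen-bond donors and acceptors differ. Of these two amides, then, the phenyl form of compound 2 has the lower number, so replacing that ring with this aminothiazole is not a neutral exchange here.

No measurement available here shows which of those differences accounts for the step. As far as these compounds go, it also remains open whether a plain 1,3-thiazol-4-yl without the amine, or a pyridyl on the same carbonyl, would stay close to compound 2 or move toward compound 3.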